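The source may report more compounds than this note shows. Statements on the series, on what has been measured and on what is new or still open speak of the compounds shown alone.

Compound 1 `CCOC(=O)c1nn(-c2ccc(Cl)cc2)c(-c2ccc(Br)cc2)c1CNC(C)(C)C`: > 511000 nM; > 476000 nM (2 entries) (limits only)
Compound 2 `CC(C)(C)NCc1c(C(=O)O)nn(-c2ccccc2)c1-c1ccc(Br)cc1`: > 585000 nM (a limit)
Compound 3 `CC(C)(C)NCc1c(C(=O)O)nn(-c2ccc(Cl)cc2)c1-c1ccc(Br)cc1`: 297000 nM

Among the compounds with values here, in a functional assay on K562 cells (Homo sapiens) for inhibition, read by sulforhodamine B assay, with a stated time of 48 h (a lower number here means a stronger inhibitor of growth, a higher number a weaker inhibitor of growth), compound 3 gives 297000 nM, and it is the only compound of the three with an actual number. Compound 2 has only a limit, > 585000 nM. Compound 1 likewise has only limits, > 511000 nM; > 476000 nM (2 entries).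

Compound 4 `CC(C)(C)NCc1c(C(=O)O)nn(-c2ccc(Cl)cc2)c1-c1ccc([N+](=O)[O-])cc1` has not yet been measured. It differs from compound 3 as follows: nitro in place of bromo on an aromatic carbon. This is a change from 4-bromophenyl to 4-nitrophenyl. Within the data shown here, the single measured step, an at least 1.9-fold lower number from compound 2 to compound 3 (0.29 log units; that floor lies within the scatter), is chloro in place of hydrogen on an aromatic carbon, a different change at a different place. Among the measured compounds shown here, no measured step replaces the bromo group, so the data give no size or direction for this change, and no shift beyond the scatter is expected in this assay. The expected outcome is a 1.0-fold higher number from compound 3 to compound 4 (0.00 log units; within the scatter). For compound 4 the estimated value is 300000 nM, with an expected range of 130000 nM to 600000 nM.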

Compound 4, concentration for 50% growth inhibition: 158000 nM
The estimate for compound 4 lay 1.9-fold (0.28 log units) above the measured number; measured number inside the range.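

In this assay, nitro in place of bromo on the aromatic carbon para to a large group gives a 1.9-fold lower number from compound 3 to compound 4 (0.27 log units; within the scatter). Within the data shown here, every earlier compound carried bromo at this position, so this is the first reading of a change there; it shows that this exchange leaves the number within the scatter, and compound 4 stands with compound 3 as a compound with an actual number, not a limit. Nothing given here bears on why the exchange reads this way.

The compounds shown leave open whether an amine, a carboxylic acid or a methoxy group at this same position would move the number beyond the scatter. They also leave open whether nitro in place of bromo would give a similar step without the chloro on the shared core.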